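The source may hold more compounds than are shown below. What is called first, only, known or untested is meant among the compounds shown, and "the series" means these compounds.

Measured in a functional assay on B16 cells (Mus musculus) for inhibition; a higher number here means a weaker inhibitor, a lower number a stronger inhibitor:
- compound 1 `COc1cc(/C=C/C(=O)c2cccc(NC(=O)c3cccs3)c2)ccc1O`: 6.93 ug/mL
- compound 2 `COc1cc(/C=C/C(=O)c2cccc(NC(=O)c3ccc(Cl)cc3)c2)ccc1O`: 0.59 ug/mL

Of these two numbers, compound 2 has the lower at 0.59 ug/mL, making it the stronger inhibitor of the pair in this assay. The next change gives compound 3 `COc1cc(/C=C/C(=O)c2cccc(NC(=O)c3ccco3)c2)ccc1O`: furan-2-yl in place of 4-chlorophenyl on a carbonyl carbon.

Within the data shown here, only one measured step bears on this change. The step of a 12-fold lower number from compound 1 to compound 2 (1.07 log units; beyond the scatter) is large and lies beyond the scatter. It brings in 4-chlorophenyl in place of thiophen-2-yl on the same carbonyl carbon, so the change to compound 3 runs the opposite way, away from 4-chlorophenyl. Furan-2-yl itself has no measurement yet, and a single step is thin support. Compound 1, with its value of 6.93 ug/mL, is still the closest available guide to a compound lacking 4-chlorophenyl. A clear move to a higher number, meaning weaker inhibition, is therefore expected, of similar order to the measured step but somewhat smaller. The expected change is an 8.5-fold higher number from compound 2 to compound 3 (0.93 log units; beyond the scatter). The estimate for compound 3 is 5 ug/mL, with an expected range from 1.5 ug/mL to 15 ug/mL.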

Compound 3, half-maximal inhibitory concentration: 5.46 ug/mL
Estimate against measurement, compound 3: 1.1-fold (0.04 log units) below; the range from low to high includes it.
By their numbers in this assay, from the lowest: compound 2; then compounds 3 and 1 (each within the scatter of the next).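

In this assay, replacing 4-chlorophenyl on this carbonyl carbon with furan-2-yl gives a 9.3-fold higher number from compound 2 to compound 3 (0.97 log units; beyond the scatter), while exchanging thiophen-2-yl for furan-2-yl gives a 1.3-fold lower number from compound 1 to compound 3 (0.10 log units; within the scatter), so the two five-membered aromatic rings cannot be told apart here. The earlier pair showed only that 4-chlorophenyl outperformed thiophen-2-yl; with a second group now tested against it, compound 2 is the strongest inhibitor of the three, and the gain no longer rests on a comparison with a single ring. No measurement is at hand that accounts for this difference between 4-chlorophenyl and the two five-membered rings.

On these data alone, it remains open whether the lower number belongs to the chlorine or to the six-membered aromatic ring itself, a question that plain phenyl on the same carbonyl carbon would address directly. Also open, as far as these compounds go, is how specific the 4-chloro substituent is, which 4-fluorophenyl, 4-methoxyphenyl or 3-chlorophenyl at this position would test, along with whether any gain carries over to assays beyond this one.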